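The compounds below may be only part of what the source reports. "The series", "measured", "known", "first", "only" and "open" are said of these compounds alone.

Of the compounds shown here, two of the shared core have been measured. Compound 1 `CCOC(=O)c1cc2c(cc1Cl)SC(N(c1ccc(OC)cc1)S(=O)(=O)c1ccc(Cl)cc1Cl)=NS2(=O)=O` gives 2300 nM in a functional assay on 5637 cells (Homo sapiens) for cytotoxicity, with a stated time of 96 h; on this read-out higher numbers stand for weaker inhibition of growth and lower numbers for stronger inhibition of growth. Compound 2 `O=C(Oc1cccc2cccnc12)c1cc2c(cc1Cl)SC(N(c1ccc(F)cc1)S(=O)(=O)c1ccc(Br)s1)=NS2(=O)=O` gives 5100 nM in this assay, the higher of the two numbers; the gap to compound 1 is beyond the scatter, and the two differ in more than one place, so no single step can be read from it. Compound 3 `O=C(Oc1cccc2cccnc12)c1cc2c(cc1Cl)SC(N(c1ccc(F)cc1)S(=O)(=O)c1ccc(Cl)cc1)=NS2(=O)=O` carries one change against compound 2: 4-chlorophenyl in place of 5-bromothiophen-2-yl on a sulfonyl sulfur. Among the measured compounds shown here, no measured pair isolates this change. A step of this kind is expected to stay within the scatter, with no direction assigned, so the expected step from compound 2 to compound 3 is a 1.1-fold lower number from compound 2 to compound 3 (0.05 log units; within the scatter). For compound 3 the expected value in this assay is 4500 nM, between 1800 nM and 11000 nM.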

Compound 3, concentration for 50% growth inhibition: 6200 nM
Compound 3: the middle estimate sits 1.4-fold (0.14 log units) below what was measured, within the range that was stated.
By their numbers in this assay, from the lowest: compound 1; then compounds 2 and 3 (each within the scatter of the next).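

Working from the first single-place step in the series, 4-chlorophenyl in place of 5-bromothiophen-2-yl on a sulfonyl sulfur gives a 1.2-fold higher number from compound 2 to compound 3 (0.08 log units; within the scatter) in this assay. In this one pair, a thiophene ring and a benzene ring at this place are therefore not separated by the read-out, and the bromine-to-chlorine exchange that comes with the ring change leaves no readable trace.

From the compounds shown here alone, whether a carboxylic acid or an amine on this ring would give a step beyond the scatter stays open, as does whether the step holds on the ethyl ester of compound 1. No evidence on any cause bears on this result.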